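The compounds below may be only part of what the source reports. "The series", "measured", "known", "first", "only" and "open" are said of these compounds alone.

Three compounds that share one core have numbers in a functional assay on HeLa cells (Homo sapiens) for antiproliferative activity, read by MTT assay, with a stated time of 48 h; a lower number here means a stronger inhibitor, a higher number a weaker inhibitor. Compound 1 `O=[N+]([O-])c1cccc(-c2nn(-c3ccccc3)cc2C(Nc2nc3ccc(Cl)cc3s2)c2c(O)ccc3ccccc23)c1`, bearing 3-nitrophenyl, gives 15500 nM. Compound 2 `COc1cccc(-c2nn(-c3ccccc3)cc2C(Nc2nc3ccc(Cl)cc3s2)c2c(O)ccc3ccccc23)c1`, bearing 3-methoxyphenyl at that spot, gives 30000 nM. Compound 3 `Oc1ccc2ccccc2c1C(Nc1nc2ccc(Cl)cc2s1)c1cn(-c2ccccc2)nc1-c1ccc(Cl)cc1`, bearing 4-chlorophenyl, gives 36800 nM. These numbers show a 1.2-fold higher number from compound 2 to compound 3 (0.09 log units; within the scatter), so that pair cannot be told apart, and a 2.4-fold higher number from compound 1 to compound 3 (0.38 log units; beyond the scatter), a modest gap.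

Compound 4 `Oc1ccc2ccccc2c1C(Nc1nc2ccc(Cl)cc2s1)c1cn(-c2ccccc2)nc1-c1cccc(Cl)c1` is still unmeasured. It has the same atoms joined differently: 3-chlorophenyl in place of 4-chlorophenyl on an aromatic carbon. In words, 3-chlorophenyl stands in place of 4-chlorophenyl on an aromatic carbon of a five-membered aromatic ring with 2 nitrogen.

Among the measured compounds shown here, no measured pair shows this kind of change directly, since none keeps the same chlorine-bearing group and alters only where the chlorine sits. The nearest guides are indirect. The exchange of one group for another on the same phenyl pattern gives a 1.9-fold higher number from compound 1 to compound 2 (0.29 log units; within the scatter), and the two steps already named are of similar small size. Across this small set, changes on this phenyl ring have moved the number only slightly, so no step beyond the scatter is expected in this assay. The estimated step is a 1.2-fold lower number from compound 3 to compound 4 (0.09 log units; within the scatter). For compound 4 the estimate is 30000 nM, with an expected range from 14000 nM to 62000 nM.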

Compound 4, half-maximal inhibitory concentration: 18300 nM
For compound 4 the middle estimate is 1.6-fold (0.21 log units) above the measured one; the range from low to high includes it.
By their numbers in this assay, from the lowest: compounds 1, 4, 2 and 3 (each within the scatter of the next, the first and the last beyond it).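

In this assay, among the compounds shown here, the pair compound 3 and compound 4 is the first to keep the chlorine and change only where it sits on the phenyl group, and it gives a 2.0-fold lower number from compound 3 to compound 4 (0.30 log units; within the scatter) so 3-chlorophenyl and 4-chlorophenyl cannot be told apart here. Swapping the group on the phenyl ring while keeping its place gives a 1.6-fold lower number from compound 2 to compound 4 (0.21 log units; within the scatter) for chloro against methoxy and a 1.2-fold higher number from compound 1 to compound 4 (0.07 log units; within the scatter) for chloro against nitro, so compounds 1, 2 and 4 also cannot be told apart, whichever of these three groups they carry. Nothing available bears on why these steps stay so small.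

Going by these compounds, whether moving a nitro or methoxy group around the phenyl ring would behave as moving the chlorine does remains open, since only chlorine appears in both places. On these data alone, all four compounds also carry a nitro, methoxy or chloro group on this phenyl ring, so it is open whether an amine or a carboxylic acid there would stay within the same narrow band of numbers or leave it.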